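Compound 3 to a 3-fluorobenzyl amide: an expected small step

The source may report more compounds than this note shows. Statements on the series, on what has been measured and on what is new or still open speak of the compounds shown alone.

Measured in a functional assay on HeLa cells (Homo sapiens) for inhibition, read by MTT assay, with a stated time of 48 h; a higher number here means a weaker inhibitor, a lower number a stronger inhibitor:
compound 1 `COc1ccc2c(=O)c(/C=C/C(=O)NCc3ccccc3)coc2c1`: 33400 nM
compound 2 `COc1ccc2c(=O)c(/C=C/C(=O)Nc3ccccc3Cl)coc2c1`: 22400 nM
compound 3 `COc1ccc2c(=O)c(/C=C/C(=O)Nc3cc(C)ccc3C)coc2c1`: 58400 nM

In this assay compound 3 gives 58400 nM. The measured steps place it modestly apart from one neighbour, with a 2.6-fold higher number from compound 2 to compound 3 (0.42 log units; beyond the scatter), and within the scatter of the other, with a 1.7-fold higher number from compound 1 to compound 3 (0.24 log units; within the scatter).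

The next compound is compound 4 `COc1ccc2c(=O)c(/C=C/C(=O)NCc3cccc(F)c3)coc2c1`, which has 3-fluorobenzyl in place of 2,5-dimethylphenyl on an amide-type nitrogen. The shared core and the linking chain stay the same.

The closest guide is the step between compound 1 and compound 3, which exchanges benzyl for 2,5-dimethylphenyl at this same place. That step is small, and the change to compound 4 runs the opposite way, from 2,5-dimethylphenyl back to a benzyl group. The other step, a 1.5-fold lower number from compound 1 to compound 2 (0.17 log units; within the scatter), is also small. Going by the values given here, no measured compound carries 3-fluorobenzyl, so the data do not show what the added fluorine does.

A small move toward a lower number is therefore expected, and the expected change is a 1.8-fold lower number from compound 3 to compound 4 (0.26 log units; within the scatter). For compound 4 the estimate is 32000 nM, with an expected range from 15000 nM to 65000 nM.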

Compound 4, half-maximal inhibitory concentration: 17600 nM
The estimate for compound 4 lay 1.8-fold (0.26 log units) above the measured number; low and high end bracket the measured number.
By their numbers in this assay, from the lowest: compounds 4, 2, 1 and 3 (each within the scatter of the next, the first and the last beyond it).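

At this amide-type nitrogen, this assay now gives a second step beyond the scatter, a 3.3-fold lower number from compound 3 to compound 4 (0.52 log units; beyond the scatter), and like the earlier one it involves the 2,5-dimethylphenyl group of compound 3, although the step from compound 1 to that compound, which goes against a simple pattern, stays within the scatter. The fluoro exchange on an aromatic carbon is the narrowest change yet seen at this place, and a 1.9-fold lower number from compound 1 to compound 4 (0.28 log units; within the scatter) shows that 3-fluorobenzyl cannot be told apart from plain benzyl in this measurement. Likewise, a 1.3-fold lower number from compound 2 to compound 4 (0.10 log units; within the scatter) leaves 3-fluorobenzyl and 2-chlorophenyl indistinguishable, so the benzyl and anilide-type amides shown here do not separate as two classes, with compound 3 alone standing apart from compounds 2 and 4. Nothing available explains why these groups compare as they do.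

The compounds shown leave open whether a phenethyl chain, a methoxy group, a carboxylic acid or an amine on the amide-type nitrogen substituent would move the number further than these aromatic groups do. They also leave open whether a methyl group in place of the amide hydrogen would change the picture.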